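The source may hold more compounds than are shown below. What is called first, only, known or untested is meant among the compounds shown, and "the series" means these compounds.

In a functional assay on Raji cells (Homo sapiens) for cytotoxicity, read by CCK-8 assay, with a stated time of 24 h (on this read-out lower numbers stand for stronger inhibition and higher numbers for weaker inhibition), compound 1 `C=CC(=O)N1C(=O)CC(c2ccc(C)cc2)Sc2ccccc21` gives 75500 nM. Compound 2 `C=CC(=O)N1C(=O)CC(c2ccccc2Cl)Sc2ccccc21` gives 50400 nM and compound 3 `C=CC(=O)N1C(=O)CC(c2ccccc2C(F)(F)F)Sc2ccccc21` gives 50300 nM, so compound 1 stands within the scatter of both. Compound 4 `C=CC(=O)N1C(=O)CC(c2ccc(C(=O)OC)cc2)Sc2ccccc21` is still unmeasured. It departs from compound 1 by methoxycarbonyl in place of methyl on an aromatic carbon, which puts methoxycarbonyl in place of methyl on an aromatic carbon, para to a large group. Among the compounds with values here, two measured steps bear on this change, though neither introduces methoxycarbonyl: a 1.5-fold lower number from compound 1 to compound 2 (0.18 log units; within the scatter) and a 1.0-fold lower number from compound 2 to compound 3 (0.00 log units; within the scatter). Both stay within the scatter, so no step beyond the scatter is expected in this assay, and no direction can be called. The estimated step is a 1.3-fold lower number from compound 1 to compound 4 (0.11 log units; within the scatter). For compound 4 the expected value is 58000 nM, with an estimated range from 28000 nM to 110000 nM.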

Compound 4, half-maximal inhibitory concentration: 89600 nM
Compound 4: the middle estimate sits 1.5-fold (0.19 log units) below what was measured; the measured number falls inside the stated range.
By their numbers in this assay, from the lowest: compounds 3, 2, 1 and 4 (each within the scatter of the next).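

In this assay, methoxycarbonyl in place of methyl on an aromatic carbon, para to a large group, gives a 1.2-fold higher number from compound 1 to compound 4 (0.07 log units; within the scatter) and so stays within the scatter. The earlier steps shown here did not test a replacement at this place alone, and here a group of 4 heavy atoms with 2 hydrogen-bond acceptors replaces methyl without a step beyond the scatter. No measurement shown accounts for this result. As far as these compounds go, whether an amine or a carboxylic acid at this place would give a step beyond the scatter stays open, and the same holds for a longer chain.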